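The compounds below may be only part of what the source reports. "The series", "measured", "known", "first", "only" and "open" are said of these compounds alone.

Among the compounds with values here, the three compounds measured so far share one core and differ in the chain on the ring nitrogen and in the sulfonamide. Compound 1 `CCCCCCCCNc1ccc(C(=O)O)cc1S(N)(=O)=O` gives 24% in an assay on HEK293 cells for inhibition of solute carrier family 12 member 2 (Homo sapiens), read by fluorescence, with a stated time of 30 min, tested at 100 uM; a higher number here means a stronger effect of the compound at the concentration tested, a lower number a weaker effect. Compound 2 `CCCCNc1ccc(C(=O)O)cc1S(=O)(=O)N(C)C` gives 15.6% in this assay, and compound 3 `CCCCCCNc1ccc(C(=O)O)cc1S(=O)(=O)N(C)C` gives 19.8% in this assay. Compound 3 thus stands second of the three numbers, though its gap to compound 1 and its gap to compound 2 both fall within the scatter of this kind of measurement, so no order among the three can be claimed.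

Compound 4 `CCCCCCCCNc1ccc(C(=O)O)cc1S(=O)(=O)N(C)C` has not yet been measured. It differs from compound 3 by ethyl in place of hydrogen on a saturated chain carbon, six bonds along the chain from a nitrogen on an aromatic ring. Within the data shown here, the one measured step that bears on this is the same kind of lengthening of the chain, a number 4.2 percentage points higher from compound 2 to compound 3 (within the scatter), which did not move the number beyond the scatter. Compound 1, which carries the same long chain as compound 4 but a different sulfonamide, shows a value close to that of compound 3. On this basis the step from compound 3 to compound 4 in this assay is expected to be small, a number 4.2 percentage points higher from compound 3 to compound 4 (within the scatter), with no clear direction. Compound 4 is therefore estimated to give 24% in this assay, within a range from 12% to 36%.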

Compound 4, a percentage reported as inhibition, at one concentration (the size of the read-out at that concentration, not a potency): 70.6%
For compound 4 the middle estimate is 46.6 percentage points below the measured one; measured number outside the range, above it.
By their numbers in this assay, from the lowest: compounds 2, 3 and 1 (each within the scatter of the next); then compound 4.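

In this assay, lengthening the chain on the ring nitrogen does not bring a steady climb but a sharp jump: ethyl in place of hydrogen, six bonds along the chain, gives a number 50.8 percentage points higher from compound 3 to compound 4 (beyond the scatter), and butyl in place of hydrogen, four bonds along the chain, gives a number 55 percentage points higher from compound 2 to compound 4 (beyond the scatter), while the earlier ethyl step gave only a number 4.2 percentage points higher from compound 2 to compound 3 (within the scatter). The group on the sulfonyl sulfur also proves to matter once the long chain is present, since dimethylamino in place of amino gives a number 46.6 percentage points higher from compound 1 to compound 4 (beyond the scatter). Among these compounds, the long chain and the dimethylamino group bring a high number only together: compound 1 has the long chain with amino, compound 3 has dimethylamino with a shorter chain, and only compound 4 has both.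

From the compounds shown here alone, whether a still longer chain would raise the number further or lower it again stays open, as does the outcome with a chain ending in an amine or with diethylamino on the sulfonyl sulfur. Nothing measured here accounts for the jump.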